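A few compounds are considered here, and "the series" means these few. Any claim that something is new, unique, unknown or untested is made for them only; others in the source may bear on it.

Within the data shown here, compound 1 `O=C(/C=C/c1cccnc1)c1nc2ccccc2[nH]1` holds the lowest number of the two compounds measured so far in a functional assay on MCF7 cells (Homo sapiens) for antiproliferative activity, read by MTT assay, with a stated time of 48 h (on this read-out lower numbers stand for stronger inhibition and higher numbers for weaker inhibition), where compound 1 gives 21700 nM. Compound 2 `O=C(/C=C/c1ccc(Br)cc1)c1nc2ccccc2[nH]1` gives 52700 nM in this assay, a gap that lies beyond the usual scatter. Compound 3 `O=C(/C=C/c1ccncc1)c1nc2ccccc2[nH]1` has the same atoms as compound 1, joined differently: pyridin-4-yl in place of pyridin-3-yl on a double-bonded chain carbon bound to a double-bonded chain carbon. Among the measured compounds shown here, no measured pair shows a step of this kind, so the step is expected to be small, a 1.1-fold lower number from compound 1 to compound 3 (0.04 log units; within the scatter), and not beyond the scatter. Compound 3 is therefore expected to give about 20000 nM, with a range of 8000 nM to 50000 nM.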

Compound 3, half-maximal inhibitory concentration: 20900 nM
For compound 3 the middle estimate is 1.0-fold (0.02 log units) below the measured one; the measured number falls inside the stated range.
By their numbers in this assay, from the lowest: compounds 3 and 1 (each within the scatter of the next); then compound 2.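

Putting pyridin-4-yl in place of pyridin-3-yl on a double-bonded chain carbon bound to a double-bonded chain carbon gives a 1.0-fold lower number from compound 1 to compound 3 (0.02 log units; within the scatter) in this assay, the first single-place step available in this series. At this place, this change therefore leaves the antiproliferative read-out within the scatter. No available evidence bears on why these two groups read alike.

From the compounds shown here alone, whether pyridin-2-yl, or a phenyl ring carrying an amine or a carboxylic acid, would read differently at this place remains open. So does the effect of changes to the shared core.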